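This account rests on a few compounds, and the source may have more. Where it says the series, first, only, none or still open, it means among the compounds named here.

In a functional assay on PC-3 cells (Homo sapiens) for inhibition, read by MTT assay, with a stated time of 48 h (a higher number here means a weaker inhibitor, a lower number a stronger inhibitor), the three measured compounds stand as follows:

compound 1 `C=C1CC[C@@H]2[C@](C)(CO)[C@H](O)CC[C@@]2(C)[C@@H]1CC(Sc1ccc(C)cc1)C1=CCOC1=O` – 29000 nM
compound 2 `C=C1CC[C@@H]2[C@](C)(CO)[C@H](O)CC[C@@]2(C)[C@@H]1CC(Sc1ccc(F)cc1)C1=CCOC1=O` – 16000 nM
compound 3 `C=C1CC[C@@H]2[C@](C)(CO)[C@H](O)CC[C@@]2(C)[C@@H]1CC(Sc1cccs1)C1=CCOC1=O` – 15000 nM

Compound 3 gives the lowest of the three numbers, but the steps of a 1.9-fold lower number from compound 1 to compound 3 (0.29 log units; within the scatter) and a 1.1-fold lower number from compound 2 to compound 3 (0.03 log units; within the scatter) both fall within the scatter, as does a 1.8-fold lower number from compound 1 to compound 2 (0.26 log units; within the scatter), so the three compounds cannot be told apart on these data. Compound 4 `C=C1CC[C@@H]2[C@](C)(CO)[C@H](O)CC[C@@]2(C)[C@@H]1CC(Sc1ncccn1)C1=CCOC1=O` has not yet been measured. It differs from compound 3 in one place: pyrimidin-2-yl in place of thiophen-2-yl on a sulfur. Going by the values given here, the steps that bear on this change are the two earlier exchanges of the aromatic group on the sulfur, a 1.9-fold lower number from compound 1 to compound 3 (0.29 log units; within the scatter) and a 1.1-fold lower number from compound 2 to compound 3 (0.03 log units; within the scatter), neither of which moved the number beyond the scatter; the exchange of a substituent on the aromatic ring, a 1.8-fold lower number from compound 1 to compound 2 (0.26 log units; within the scatter), was likewise small. Among the compounds with values here, nothing among the measured compounds points to a shift beyond the scatter when one aromatic group on the sulfur replaces another. Compound 4 is therefore expected to show the step of no change at the digits printed from compound 3 to compound 4 (within the scatter). In this assay compound 4 is estimated at 15000 nM, with a range from 5000 nM to 45000 nM.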

Compound 4, half-maximal inhibitory concentration: 7000 nM
Beside the measured number, compound 4's estimate is 2.1-fold (0.33 log units) above it; measured number inside the range.
By their numbers in this assay, from the lowest: compound 4; then compounds 3, 2 and 1 (each within the scatter of the next).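

In this assay, the aromatic group on the sulfur turns out not to be interchangeable: pyrimidin-2-yl, a six-membered aromatic ring with 2 hetero atoms, gives a step beyond the scatter (a 2.1-fold lower number from compound 3 to compound 4 (0.33 log units; beyond the scatter)), which no exchange among compound 1, compound 2 and compound 3 did. The same group also passes the scatter against the substituted phenyl groups (a 2.3-fold lower number from compound 2 to compound 4 (0.36 log units; beyond the scatter); a 4.1-fold lower number from compound 1 to compound 4 (0.62 log units; beyond the scatter)), though all of these steps remain modest. Nothing offered here accounts for why this group stands apart.

The compounds shown leave open whether the result depends on the ring nitrogen atoms or on the ring as a whole, which a pyridin-2-yl group on the sulfur could help to separate. They also leave open whether an amine on the pyrimidine ring, or a saturated chain such as butyl in place of the ring, would keep the lower number.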